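Adding an Isopropyl to the Phenyl of Compound 1

A few compounds are considered here, and "the series" means these few. Any claim that something is new, unique, unknown or untested is made for them only; others in the source may bear on it.

Measured compounds:
compound 1, `COc1ccc(Nc2nc(SCc3cn(Cc4ccccc4Cl)nn3)nc(-c3ccccc3)c2C#N)cc1`, gives 7560 nM in a functional assay on MGC-803 cells (Homo sapiens) for inhibition, read by MTT assay, with a stated time of 72 h; a lower number here means a stronger inhibitor, a higher number a weaker inhibitor
compound 2, `N#Cc1c(Nc2ccccc2Cl)nc(SCc2cn(Cc3ccccc3Cl)nn2)nc1-c1ccccc1`, gives 4640 nM in this assay

Going by the values given here, only two compounds have been measured, and compound 1 is the one with the higher number of the two; the step of a 1.6-fold lower number from compound 1 to compound 2 (0.21 log units; within the scatter) lies within the scatter, so the two cannot be told apart on these numbers. That step exchanges the group on the amine nitrogen and says nothing about the phenyl ring on the shared core.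

Compound 3, `COc1ccc(Nc2nc(SCc3cn(Cc4ccccc4Cl)nn3)nc(-c3ccc(C(C)C)cc3)c2C#N)cc1`, differs from compound 1 by isopropyl in place of hydrogen on an aromatic carbon. Among the compounds with values here, no measured step touches this ring, so there is no guide from the data; the only step known is at another site and was itself within the scatter. The expectation is therefore no change beyond the scatter, that is a 1.2-fold lower number from compound 1 to compound 3 (0.07 log units; within the scatter). Compound 3 is estimated at 6500 nM, with a range from 2500 nM to 17000 nM.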

Compound 3, half-maximal inhibitory concentration: > 64000 nM
Compound 3 was reported as a limit (the forecaster's own chance of this, stated with the estimate: 5%); middle value at least 9.8-fold (0.99 log units) away from the limit.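

Going by these compounds alone, compound 3 shows that the phenyl ring on the shared core, which no earlier step touched, is sensitive to change. In this assay, within the data shown here, isopropyl in place of hydrogen on an aromatic carbon, para to a large group, gives an at least 8.4-fold higher number from compound 1 to compound 3 (0.92 log units; beyond the scatter), whereas the only earlier step, at the amine nitrogen, stayed within the scatter. For compound 3, the reading of > 64000 nM is a limit of the assay and not a number: the limit of > 64000 nM in this assay, at which 1 of the 3 values shown sits.

The direction of this step is therefore clear, but its full size is not, and a single group cannot show whether the change depends on isopropyl itself or would follow from any group on this carbon. A methyl or an amine at the same place would help to separate these possibilities, and isopropyl on compound 2 would test whether the step carries over to another group on the amine nitrogen.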